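The source may report more compounds than this note shows. Statements on the series, on what has been measured and on what is new or still open speak of the compounds shown alone.

Measured so far in a functional assay on MIA PaCa-2 cells (Homo sapiens) for inhibition, read by MTT assay, with a stated time of 72 h; on this read-out higher numbers stand for weaker inhibition and lower numbers for stronger inhibition:
- Compound 1 `COc1cc(NC(C)CCCNC(=O)NNC(=O)Nc2ccc(Cl)cc2)c2ncccc2c1`: >= 250000 nM
- Compound 2 `COc1cc(NC(C)CCCNC(=O)Nc2cc(C(F)(F)F)cc(C(F)(F)F)c2)c2ncccc2c1`: 4700 nM

The entry for compound 1 is a limit of the assay and not a number, so this compound has no exact position in the series. (the limit of >= 250000 nM in this assay, at which 1 of the 2 values shown sits).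

Compound 3 `COc1cc(NC(C)CCCNC(=O)Nc2ccc(Cl)cc2)c2ncccc2c1` is the next compound to be read in this assay. It has not yet been measured. Compared with compound 1, the change is 4-chlorophenyl in place of ((4-chlorophenyl)carbamoyl)amino on an amide-type nitrogen. In words, 4-chlorophenyl stands in place of ((4-chlorophenyl)carbamoyl)amino on an amide-type nitrogen, while the rest of the structure stays the same.

For the measured compounds named here, no measured step covers this change, so any expectation is rough. The nearest guide is compound 2, which also lacks the ((4-chlorophenyl)carbamoyl)amino group and gives 4700 nM. On that basis, a large step toward stronger inhibition, well beyond the scatter, is expected: the estimated step is an at least 16-fold lower number from compound 1 to compound 3 (1.22 log units; beyond the scatter). The size of this step stays approximate, as one end of it is only a limit.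

The expected value for compound 3 is 15000 nM, with an estimated range of 4000 nM to 60000 nM.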

Compound 3, half-maximal inhibitory concentration: 22000 nM
For compound 3 the middle estimate is 1.5-fold (0.17 log units) below the measured one; the measured number falls inside the stated range.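

In this assay, the place on the amide-type nitrogen whose other neighbour is the carbonyl carbon now has a direct reading: 4-chlorophenyl in place of ((4-chlorophenyl)carbamoyl)amino gives an at least 11-fold lower number from compound 1 to compound 3 (1.05 log units; beyond the scatter). Both the leaving and the entering group carry a six-membered aromatic ring of carbon only and a chlorine, so the chlorinated ring alone does not separate the two compounds; what differs is the linking part, and the leaving group has 2 hydrogen-bond donors and 1 hydrogen-bond acceptor where the entering group has none. The entry for compound 1 is a limit and not a number, so this step gives only a minimum size: the limit of >= 250000 nM in this assay, at which 1 of the 3 values shown sits.

The compounds shown leave open which part of the leaving group's linker accounts for the step, as no compound keeps only part of it. They also leave open how this position responds to an amine or a carboxylic acid in place of the chlorine, or to a methylene spacer between the amide-type nitrogen and the phenyl ring.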